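The source may report more compounds than this note shows. Statements on the series, on what has been measured and on what is new or still open speak of the compounds shown alone.

Working notes on the series. Compound 1 `Fc1ccc(-c2nn3c(NC4CCCC4)cccc3c2-c2ccnc(NC3CCCC3)n2)cc1` stands at a limit in an ADME assay on Vero cells (Chlorocebus sabaeus) for cytotoxicity; on this read-out higher numbers stand for lower toxicity in this test and lower numbers for higher toxicity in this test: in this assay compound 1 gives > 160000 nM, which is a limit of the assay and not a number. Of the two values shown, compound 1 sits at the limit of > 160000 nM in this assay, at which 1 of the 2 values shown sits. Compound 2 `c1cc(-c2c(-c3ccc(OCC4CC4)cc3)nn3c(NC4CCCC4)nccc23)nc(NC2CCCC2)n1` is the other member with a reading in this assay. In this assay compound 2 gives > 40000 nM, again a limit and not a number, namely (the limit of > 40000 nM in this assay, at which 1 of the 2 values shown sits). Among the compounds with values here, no pair of measured compounds differing in one place is available, so no measured size of step exists in this assay.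

Compound 3 `c1cc(NC2CCCC2)n2nc(-c3ccc(OCC4CC4)cc3)c(-c3ccnc(NC4CCCC4)n3)c2c1` is not yet measured. It differs from compound 1 by cyclopropylmethoxy in place of fluoro on an aromatic carbon. With both readings in this assay sitting at limits, the step is expected to be none beyond the scatter, and the expected change from compound 1 to compound 3 is put at an at least 1.6-fold lower number from compound 1 to compound 3 (0.20 log units; that floor lies within the scatter). Compound 3 is accordingly estimated at 100000 nM, with a range from 30000 nM to 300000 nM, and a reading that again comes back only as a limit is considered the more likely outcome.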

Compound 3, half-maximal cytotoxic concentration: > 40000 nM
Compound 3: only a limit was reported; the forecaster's own chance of this, stated with the estimate: 70%; the middle value lies beyond the limit too.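

In this assay, within the data shown here, compound 1 and compound 3 both come back as limits and not as numbers, so no step between them can be read. The compounds shown leave open whether 4-(cyclopropylmethoxy)phenyl in place of 4-fluorophenyl changes the reading in this assay at all, and where compound 1, compound 2 and compound 3 would fall as numbers.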